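Bromo to Amino on a Saturated Chain Carbon

A few compounds are considered here, and "the series" means these few. Any claim that something is new, unique, unknown or untested is made for them only; others in the source may bear on it.

In a functional assay on A2780 cells (Homo sapiens) for antiproliferative activity, read by MTT assay, with a stated time of 48 h (on this read-out higher numbers stand for weaker inhibition and lower numbers for stronger inhibition), compound 1 (`COc1ccc(C(=O)c2ccc(OC)c3c2C=CC(C)(C)O3)c(NC(=O)CBr)c1`) gives 2150 nM. Compound 2 (`COc1ccc(C(=O)c2ccc3c(c2)C=CC(C)(C)O3)c(NC(=O)CBr)c1`) gives 1870 nM, within the scatter of compound 1, so these two stand level at the top of the three numbers. Compound 3 (`COc1ccc(C(=O)c2ccc(OC)c3c2OC(C)(C)C=C3)c(NC(=O)CO)c1`) gives 100 nM, far lower than compound 1. Compound 3 differs from compound 1 in more than one place, so that gap isolates no single change.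

Compound 4 (`COc1ccc(C(=O)c2ccc(OC)c3c2C=CC(C)(C)O3)c(NC(=O)CN)c1`), not yet measured, has amino in place of the bromo of compound 1, on a saturated chain carbon bound to a carbonyl carbon: amino in place of bromo on a saturated chain carbon bound to a carbonyl carbon. Going by the values given here, no measured pair tests this change alone. Among the compounds with values here, the only guide is compound 3, which carries no bromo and reaches 100 nM. In this assay a step beyond the scatter toward stronger inhibition is therefore expected, though a smaller one than the gap to compound 3. The expected step is a 6.1-fold lower number from compound 1 to compound 4 (0.79 log units; beyond the scatter). For compound 4 the estimated value is 350 nM, with an expected range of 70 nM to 1700 nM.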

Compound 4, half-maximal inhibitory concentration: 890 nM
Compound 4: middle estimate off by 2.5-fold (0.41 log units), on the low side, within the range that was stated.
By their numbers in this assay, from the lowest: compound 3; then compound 4; then compounds 2 and 1 (each within the scatter of the next).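

Going by these compounds alone, the step of a 2.4-fold lower number from compound 1 to compound 4 (0.38 log units; beyond the scatter) in this assay is the only change here read on its own, and it shows that activity at this saturated chain carbon bound to a carbonyl carbon does not depend on the bromo. Amino, which brings a hydrogen-bond donor and a hydrogen-bond acceptor where bromo has none, gives a modest gain on the core of compound 1. No measurement available here accounts for this step.

The compounds shown leave open whether a dimethylamino group, a carboxylic acid or a longer chain carrying the amino group on this carbon would move the number further. The hydroxy of compound 3 also remains unread at this carbon, since compound 3 differs from compound 1 and compound 4 in more than one place.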